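Ester Chain Replaces Cyclopentyl on the Shared Core

The source may report more compounds than this note shows. Statements on the series, on what has been measured and on what is new or still open speak of the compounds shown alone.

Compound 3 `O=c1c2ccccc2c(-c2cccnc2)nn1C1CCCC1` stands highest of the three numbers measured in an assay on isolated protein (Oryctolagus cuniculus) with Thromboxane-A synthase (Homo sapiens) as the target, tested at 1 uM; a higher number here means more inhibition at the concentration tested (going by the name of the read-out), a lower number less inhibition: compound 3 gives 97%, while compound 2 `CC(C)n1nc(-c2cccnc2)c2ccccc2c1=O` gives 87% and compound 1 `Cn1nc(-c2cccnc2)c2ccccc2c1=O` gives 63%. The step of a number 34 percentage points higher from compound 1 to compound 3 (beyond the scatter) is large and the step of a number 24 percentage points higher from compound 1 to compound 2 (beyond the scatter) is modest, whereas the step of a number 10 percentage points higher from compound 2 to compound 3 (within the scatter) lies within the scatter. Compound 4 `CCOC(=O)Cn1nc(-c2cccnc2)c2ccccc2c1=O` differs from compound 3 by (ethoxycarbonyl)methyl in place of cyclopentyl on an aromatic nitrogen. For the measured compounds named here, the measured steps concern only methyl, isopropyl and cyclopentyl on that nitrogen; none concerns an (ethoxycarbonyl)methyl group, so no step bears directly on this change. The account therefore expects for compound 4 a modest fall in this assay, estimated as a number 22 percentage points lower from compound 3 to compound 4 (beyond the scatter). Compound 4 is expected to give 75%, within 50% to 92%.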

Compound 4, a percentage reported as inhibition, at one concentration (the size of the read-out at that concentration, not a potency): 28%
Compound 4: middle estimate off by 47 percentage points, on the high side; measured number outside the range, below it.
By their numbers in this assay, from the lowest: compound 4; then compound 1; then compounds 2 and 3 (each within the scatter of the next).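

The rise seen from methyl through isopropyl to cyclopentyl on this nitrogen does not extend to every group: (ethoxycarbonyl)methyl brings a number 69 percentage points lower from compound 3 to compound 4 (beyond the scatter) and a number 59 percentage points lower from compound 2 to compound 4 (beyond the scatter) in this assay. The ester chain even falls short of the small methyl group, with a number 35 percentage points lower from compound 1 to compound 4 (beyond the scatter) on adding ethoxycarbonyl to that carbon. So this position is sensitive to the kind of group it carries, not only to moving beyond methyl.

On these data alone, how the free carboxylic acid or a plain butyl chain on that nitrogen would read remains open. Nothing available here accounts for the fall.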